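Side-chain carbon count and compound 4

A few compounds are considered here, and "the series" means these few. Any claim that something is new, unique, unknown or untested is made for them only; others in the source may bear on it.

Going by the values given here, in a functional assay (Nicotiana tabacum) (a higher number here means a weaker inhibitor, a lower number a stronger inhibitor), compound 1 `CCCNc1nc(SC)nc2ncccc12` gives 270 nM, the lowest number so far. Compound 2 `CCC(C)Nc1nc(SC)nc2ncccc12` gives 860 nM, and compound 3 `CCC(CC)Nc1nc(SC)nc2ncccc12` gives 2720 nM.

Compound 4 `CCCCC(CC)CNc1nc(SC)nc2ncccc12` carries 1-ethylpentyl in place of ethyl on a saturated chain carbon bound to a nitrogen on an aromatic ring.

The nearest evidence comes from changes on that same carbon. Methyl in place of hydrogen gives a 3.2-fold higher number from compound 1 to compound 2 (0.50 log units; beyond the scatter), and ethyl in place of hydrogen gives a 10-fold higher number from compound 1 to compound 3 (1.00 log units; beyond the scatter). The further step adds methyl and gives a 3.2-fold higher number from compound 2 to compound 3 (0.50 log units; beyond the scatter). Among these three compounds, each added carbon group goes with a higher number, and none goes against this. None of the steps replaces ethyl, however, and none reaches a chain as long as 1-ethylpentyl, so the guidance is loose. A modest rise is expected in this assay, with the estimated step being a 3.3-fold higher number from compound 1 to compound 4 (0.52 log units; beyond the scatter). Compound 4 is estimated at 900 nM, with an expected range of 200 nM to 4000 nM.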

Compound 4, half-maximal inhibitory concentration: 15900 nM
Compound 4: middle estimate off by 18-fold (1.25 log units), on the low side; the whole stated range lies below it.
By their numbers in this assay, from the lowest: compound 1; then compound 2; then compound 3; then compound 4.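

With 1-ethylpentyl in place of ethyl on a saturated chain carbon bound to a nitrogen on an aromatic ring, this assay shows a large step, a 59-fold higher number from compound 1 to compound 4 (1.77 log units; beyond the scatter), well past the modest steps seen with the smaller groups. The rise therefore does not level off at this position as the added group grows: across the four compounds, each larger group goes with a higher number, and none goes against this. No measurement shown here explains why the step is so large.

Still open, on these data alone, is whether the rise follows total carbon count or branching, which an unbranched longer chain such as n-hexyl would help to separate. Also open, as far as these compounds go, is whether a chain of similar length ending in a hydroxyl group or an amine would give a similarly high number.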